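The source may hold more compounds than are shown below. What is called first, only, known or untested is meant among the compounds shown, and "the series" means these compounds.

Going by the values given here, in a functional assay, read by spectrophotometry, with a stated time of 1 h (a higher number here means a weaker inhibitor, a lower number a stronger inhibitor), compound 3 `O=c1cc(/C=N\c2ccc(O)cc2)c2c(OCc3ccccc3)cc(OCc3ccccc3)cc2o1` gives 107000 nM as the lowest of the two actual numbers so far. Compound 1 `Nc1ccccc1/N=C\c1cc(=O)oc2cc(OCc3ccccc3)cc(OCc3ccccc3)c12` gives 624000 nM as the nearest number. Compound 2 `N/N=C\c1cc(=O)oc2cc(OCc3ccccc3)cc(OCc3ccccc3)c12` gives > 2000000 nM as its result, and this is a limit of the assay and not a number.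

Compound 4 `O=c1cc(/C=N\Nc2ccccc2)c2c(OCc3ccccc3)cc(OCc3ccccc3)cc2o1` has not yet been measured and differs from compound 3 by a single change anilino in place of 4-hydroxyphenyl on a double-bonded nitrogen with anilino in place of 4-hydroxyphenyl on a double-bonded nitrogen. Two measured steps changed the group at that same place, with a 5.8-fold lower number from compound 1 to compound 3 (0.77 log units; beyond the scatter) as a modest one and an at least 18-fold lower number from compound 2 to compound 3 (1.27 log units; beyond the scatter) as a large one. Both ended on the 4-hydroxyphenyl that compound 4 gives up, so a modest move to a higher number is expected in this assay rather than no change beyond the scatter. The expected size is a 2.8-fold higher number from compound 3 to compound 4 (0.45 log units; beyond the scatter) on this reading. For compound 4 the estimate is 300000 nM with an expected range from 80000 nM to 1200000 nM for the measurement.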

Compound 4, half-maximal inhibitory concentration: 401000 nM
For compound 4 the middle estimate is 1.3-fold (0.13 log units) below the measured one; measured number inside the range.
By their numbers in this assay, from the lowest: compound 3; then compounds 4 and 1 (each within the scatter of the next). At a limit, above all of these: compound 2.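

Among the larger groups on this double-bonded nitrogen, anilino and 2-aminophenyl cannot be told apart (a 1.6-fold lower number from compound 1 to compound 4 (0.19 log units; within the scatter)), whereas 4-hydroxyphenyl stays clearly ahead of anilino (a 3.7-fold higher number from compound 3 to compound 4 (0.57 log units; beyond the scatter)). Phenyl in place of hydrogen on the amine nitrogen also improves on the bare amino group (an at least 4.9-fold lower number from compound 2 to compound 4 (0.69 log units; beyond the scatter)), so a ring on that nitrogen helps even when it is held one atom further out, as in anilino. Compound 2 itself gives a limit and not a number, so that step has no exact size: the limit of > 2000000 nM in this assay, at which 1 of the 4 values shown sits.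

Compound 3 and compound 4 differ both in the linking nitrogen and in the hydroxyl, so the two contributions cannot be separated. A plain phenyl or a 4-hydroxyanilino group at this place would pull them apart.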